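From methoxy to methyl at the assay limit

The source may report more compounds than this note shows. Statements on the series, on what has been measured and on what is new or still open speak of the compounds shown alone.

Of the compounds shown here, two have been tested so far in a functional assay on the whole organism for positive allosteric modulation, with Mus musculus as the target (a lower number here means that less compound is needed, a higher number that more compound is needed for the effect), and neither gives a number. Compound 1 `CCC(=O)N(c1ccc(Cl)cc1)C1CCCC1N(C)C` gives > 50 mg/kg as a limit of the assay, not a number. Compound 2 `CCC(=O)N(c1ccc(OC)cc1)C1CCCCC1N(C)C` likewise gives > 50 mg/kg as a limit, so where it stands is known only as a limit. The whole record so far is the limit of > 50 mg/kg in this assay, at which 2 of the 2 values shown sit, and it contains no measured dose.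

Compound 3 `CCC(=O)N(c1ccc(C)cc1)C1CCCCC1N(C)C` has not yet been measured. It differs from compound 2 by methyl in place of methoxy on an aromatic carbon and the change sits para to a large group. For the measured compounds named here, no step between measured compounds is available to guide the estimate, so no change beyond the usual scatter is expected in this assay and neither direction is favoured. The expected change is a number no higher from compound 2 to compound 3 (the limit leaves the size open) on this reading. This expectation rests on compound 2 at > 50 mg/kg as a limit. The estimated dose for compound 3 is 50 mg/kg with an expected range from 20 mg/kg to 100 mg/kg and a limit of the assay is the likeliest expected outcome.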

Compound 3, dose for half-maximal effect: > 50 mg/kg
Compound 3: no number, only a limit; the forecaster's own chance of this, stated with the estimate: 70%; the middle value sits exactly at the limit.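

In this assay, for the compounds shown here, compound 3 gives only a limit, as compound 2 does, so no step from methoxy to methyl can be read between these two compounds. The compounds shown leave open what dose of any of them would give the effect in this assay: the limit of > 50 mg/kg in this assay, at which 3 of the 3 values shown sit.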